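This account rests on a few compounds, and the source may have more. Where it says the series, first, only, none or still open, it means among the compounds named here.

Measured so far:
- compound 1 `CC(=O)OC/C(=C\c1ccc(Cl)cc1)C(=O)c1ccccc1`: 4800 nM
- compound 2 `CC(=O)OC/C(=C\C1CCCCC1)C(=O)c1ccc(Cl)cc1`: 21000 nM

In a functional assay on WiDr cells (Homo sapiens) for inhibition, read by sulforhodamine B assay, with a stated time of 48 h (a lower number here means a stronger inhibitor of growth, a higher number a weaker inhibitor of growth), compound 2 gives 21000 nM, the higher of the two numbers shown. In this assay compound 1 gives 4800 nM, a lower number that lies beyond the usual scatter. Compound 3 `CC(=O)OC/C(=C\c1ccc(Cl)cc1)C(=O)c1ccc(Cl)cc1` is not yet measured. It arises from compound 2 by 4-chlorophenyl in place of cyclohexyl on a double-bonded chain carbon bound to a double-bonded chain carbon, so that compound 3 carries a 4-chlorophenyl group at each end of the shared core, and shares the 4-chlorobenzylidene part with compound 1. For the measured compounds named here, no step between measured compounds that differ in a single place is available, so the expectation rests on compound 1 with 4800 nM alone. The step from compound 2 to compound 3 is expected to be a 3.8-fold lower number from compound 2 to compound 3 (0.58 log units; beyond the scatter) in this assay, a lower number by more than the scatter. Compound 3 is therefore estimated at 5500 nM in this assay, with a range from 2000 nM to 15000 nM.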

Compound 3, concentration for 50% growth inhibition: 18000 nM
Beside the measured number, compound 3's estimate is 3.3-fold (0.51 log units) below it, and the stated range ends below it.
By their numbers in this assay, from the lowest: compound 1; then compounds 3 and 2 (each within the scatter of the next).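

In this assay, 4-chlorophenyl in place of cyclohexyl on a double-bonded chain carbon bound to a double-bonded chain carbon gives a 1.2-fold lower number from compound 2 to compound 3 (0.07 log units; within the scatter), so with the chloro group on the other ring, these two groups are not told apart at this place. The other new step, chloro in place of hydrogen on an aromatic carbon, gives a 3.8-fold higher number from compound 1 to compound 3 (0.57 log units; beyond the scatter), which is the only change in this set shown to move the number beyond the scatter. No measurement offered here accounts for either step.

On these data alone, whether the chloro step would hold with cyclohexyl in place of 4-chlorophenyl remains open. Also open, as far as these compounds go, is how an amine, a carboxylic acid or a longer chain would behave at this place.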